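Working notes: carboxy added to the benzyl of compound 2

The source may report more compounds than this note shows. Statements on the series, on what has been measured and on what is new or still open speak of the compounds shown alone.

Measured compounds in an assay on isolated protein for inhibition of sodium-dependent phosphate transport protein 2B (Homo sapiens); a lower number here means a stronger inhibitor, a higher number a weaker inhibitor:
compound 1, `CCC(CC)N(CCN(C)C(=O)CCC(=O)O)Cc1cccc(C(=O)Nc2sc3c(c2C(=O)c2cnn(-c4ccc(Cl)cc4)c2)CCC(C)(C)C3)c1`, gives 36 nM
compound 2, `CCC(CC)N(CCN(C)C(=O)CCC(=O)O)Cc1cccc(C(=O)Nc2sc3c(c2C(=O)c2cnn(Cc4ccccc4)c2)CCC(C)(C)C3)c1`, gives 179 nM

Among the compounds with values here, compound 2 stands at the higher of the two numbers; the only measured step, a 5.0-fold higher number from compound 1 to compound 2 (0.70 log units; beyond the scatter), lies beyond the scatter, so compound 2 is the weaker of the pair. Compound 3, `CCC(CC)N(CCN(C)C(=O)CCC(=O)O)Cc1cccc(C(=O)Nc2sc3c(c2C(=O)c2cnn(Cc4ccc(C(=O)O)cc4)c2)CCC(C)(C)C3)c1`, differs from compound 2 by carboxy in place of hydrogen on an aromatic carbon. Within the data shown here, no measured step bears on this change: the single step on record exchanges the whole group on the aromatic nitrogen and offers no guide to a carboxy placed on the ring of the benzyl. With nothing to anchor a direction, compound 3 is expected to sit close to compound 2, within the scatter, and any step is expected to be small: a 1.1-fold lower number from compound 2 to compound 3 (0.02 log units; within the scatter). Compound 3 is therefore estimated at 170 nM, with a wide range from 45 nM to 650 nM.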

Compound 3, half-maximal inhibitory concentration: > 1000 nM
Compound 3 was reported as a limit; the forecaster's own chance of this, stated with the estimate: 5%; middle value at least 5.8-fold (0.76 log units) away from the limit.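

In this assay, the benzyl ring does not accept every substituent: carboxy in place of hydrogen on an aromatic carbon, para to a large group, gives an at least 5.5-fold higher number from compound 2 to compound 3 (0.74 log units; beyond the scatter). Exchanging 4-chlorophenyl on the aromatic nitrogen for 4-carboxybenzyl gives an at least 27-fold higher number from compound 1 to compound 3 (1.44 log units; beyond the scatter), so the group on that nitrogen spans a wider range than the earlier pair showed. Compound 3 stands only as a limit, not as a number: the limit of > 1000 nM in this assay, at which 1 of the 3 values shown sits.

Going by these compounds, it remains open whether the weakening belongs to the carboxylic acid itself or would also follow a methyl ester, a primary amide or a hydroxymethyl group at the same place on the benzyl. Also open, on these data alone, is how a carboxylic acid would fare on the 4-chlorophenyl group of compound 1.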